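The compounds below may be only part of what the source reports. "The series", "measured", "known", "first", "only" and "open" are said of these compounds alone.

Compound 1 `Nc1ncnc2c1c(-c1ccc(NC(=O)c3ccccc3)cc1)cn2[C@H]1CCN(C[C@@H]2CO2)C1` carries a benzamido group on the aryl ring attached to the shared core, and in a functional assay on JeKo-1 cells (Homo sapiens) for antiproliferative activity (on this read-out lower numbers stand for stronger inhibition and higher numbers for weaker inhibition), compound 1 gives 5390 nM. Compound 2 `Nc1ncnc2c1c(-c1ccc(Oc3ccccc3)cc1)cn2[C@H]1CCN(C[C@@H]2CO2)C1` has a phenoxy group at that position instead; in this assay compound 2 gives 1480 nM, so the change described as benzamido in place of phenoxy on an aromatic carbon gives a 3.6-fold lower number from compound 1 to compound 2 (0.56 log units; beyond the scatter). Compound 3 `CC(C)(C)c1ccc(Oc2ccc(-c3cn([C@H]4CCN(C[C@@H]5CO5)C4)c4ncnc(N)c34)cc2)cc1` adds a tert-butyl group to the phenoxy ring of compound 2, and in this assay compound 3 gives 14800 nM. The change from compound 2 to compound 3 is tert-butyl in place of hydrogen on an aromatic carbon, and it gives a 10-fold higher number from compound 2 to compound 3 (1.00 log units; beyond the scatter).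

Compound 4 `CC(C)(C)c1ccc(C(=O)Nc2ccc(-c3cn([C@H]4CCN(C[C@@H]5CO5)C4)c4ncnc(N)c34)cc2)cc1` is not yet measured. It differs from compound 1 by tert-butyl in place of hydrogen on an aromatic carbon, the same change that was made from compound 2 to compound 3, here on the benzamido core rather than the phenoxy core, the two cores differing by benzamido in place of phenoxy on an aromatic carbon. Because the earlier step was a 10-fold higher number from compound 2 to compound 3 (1.00 log units; beyond the scatter), compound 4 is expected to show a weakening of similar size, a 5.6-fold higher number from compound 1 to compound 4 (0.75 log units; beyond the scatter). In this assay compound 4 is therefore estimated at 30000 nM, between 10000 nM and 90000 nM.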

Compound 4, half-maximal inhibitory concentration: 3290 nM
Compound 4: middle estimate off by 9.1-fold (0.96 log units), on the high side; the whole stated range lies above it.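

In this assay, tert-butyl in place of hydrogen on the benzamido ring gives a 1.6-fold lower number from compound 1 to compound 4 (0.21 log units; within the scatter), so compound 4 cannot be told apart from compound 1. Among the compounds shown here, the change therefore does not carry over from the phenoxy core of compound 2 to the benzamido core of compound 1, as the two steps clearly differ: the same change on two cores in this assay, a 10-fold higher number (1.00 log units; beyond the scatter) from compound 2 to compound 3 and a 1.6-fold lower number (0.21 log units; within the scatter) from compound 1 to compound 4, 16-fold (1.21 log units) apart, beyond the scatter of two such steps With only one pair on each core, this shows that the outcome of the change depends on the core in these four compounds, but it does not show why, nor how the change would behave on any other core or in any other assay.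

The compounds shown leave open whether a methyl, a methoxy or an amine in place of the tert-butyl would separate the two cores in the same way. They also leave open whether a sulfonamide link in place of the amide would follow the benzamido pair or the phenoxy pair.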